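The source may report more compounds than this note shows. Statements on the series, on what has been measured and on what is new or still open speak of the compounds shown alone.

Three compounds that share one core were tested in a functional assay on PC-12 cells (Rattus norvegicus) for cytotoxicity, read by MTT assay, with stated times of 2 h and 24 h, tested at 5 uM; on this read-out lower numbers stand for a weaker effect and higher numbers for a stronger effect at the one concentration tested. Compound 1 `Oc1cc(C(F)(F)F)ccc1-c1nc(-c2ccccc2O)n(-c2ccccc2F)n1` gives 86.6%. Compound 2 `Oc1cc(C(F)(F)F)ccc1-c1nc(-c2ccccc2O)n(-c2ccccc2Cl)n1` gives 90.6%, and the step of a number 4 percentage points higher from compound 1 to compound 2 (within the scatter) comes from the change (chloro in place of fluoro on an aromatic carbon). Compound 3 `Oc1cc(C(F)(F)F)ccc1-c1nc(-c2ccccc2O)n(-c2cccc(F)c2)n1` gives 87.7%; its core differs from the core of compound 1 by 3-fluorophenyl in place of 2-fluorophenyl on an aromatic nitrogen, and the steps of a number 1.1 percentage points higher from compound 1 to compound 3 (within the scatter) and a number 2.9 percentage points lower from compound 2 to compound 3 (within the scatter) are both small. Compound 4 `Oc1cc(C(F)(F)F)ccc1-c1nc(-c2ccccc2O)n(-c2cccc(Cl)c2)n1` has not yet been measured in this assay. It differs from compound 3 by chloro in place of fluoro on an aromatic carbon. Within the data shown here, this is the same kind of change as the one from compound 1 to compound 2, though the place is not the same: in compound 1 the fluoro sits ortho to a large group, in compound 3 it sits meta to a large group. Because the earlier step was a number 4 percentage points higher from compound 1 to compound 2 (within the scatter), a step of about a number 2.3 percentage points higher from compound 3 to compound 4 (within the scatter) is expected here as well. For compound 4 a value near 90% is expected, most likely between 82% and 96%.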

Compound 4, a percentage reported as activity, at one concentration (the size of the read-out at that concentration, not a potency): 92.7%
Estimate against measurement, compound 4: 2.7 percentage points below; measured number inside the range.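

Carried from the core of compound 1 to the core of compound 3, chloro in place of fluoro gave matching results in this assay: the same change on two cores in this assay, a number 4 percentage points higher (within the scatter) from compound 1 to compound 2 and a number 5 percentage points higher (within the scatter) from compound 3 to compound 4, 1 percentage points apart, within the scatter of two such steps. The new step is a number 5 percentage points higher from compound 3 to compound 4 (within the scatter), and the two steps that move the halogen or change both the halogen and its place are a number 2.1 percentage points higher from compound 2 to compound 4 (within the scatter) and a number 6.1 percentage points higher from compound 1 to compound 4 (within the scatter). The agreement shows that this change left the read-out within normal scatter on both cores, but it does not show that chloro truly raises the read-out, and two cores cannot show that the same would hold on others.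

As far as these compounds go, all four compounds carry only fluoro or chloro on this phenyl ring, so it remains open how a methoxy group, an amine or a carboxylic acid at the same place would read. The two hydroxyl groups and the trifluoromethyl group are also the same throughout, leaving open what replacing any of them would do.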